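Chain shortening in a side-chain amide series: compound 4

This account rests on a few compounds, and the source may have more. Where it says the series, first, only, none or still open, it means among the compounds named here.

Measured compounds:
Compound 1 `O=C(OCc1ccccc1)[C@@H]1CCCN1C(=O)CN(c1nc(Cl)nc2[nH]cnc12)C1CC1`: 34.4%
Compound 2 `NC(=O)CC[C@H](NC(=O)CN(c1nc(Cl)nc2[nH]cnc12)C1CC1)C(=O)O`: 38.4%
Compound 3 `NC(=O)CC[C@H](NC(=O)CN(c1nc(Cl)nc2[nH]cnc12)C1CC1)C(=O)OCc1ccccc1`: 33.1%

All three share one core and were read in a functional assay on the whole organism (Tail, strain ICR) with Mus musculus as the target, in the tail flick test, with a stated time of 60 min, at a dose of 25 umol/kg by the oral route; a lower number here means a weaker effect, a higher number a stronger effect of the compound at the dose given. The number for compound 2 is the largest of the three shown, but its gaps to compound 1 and to compound 3 are both within the scatter, so the three are not separated. Among the compounds with values here, the only single-point step measured, a number 5.3 percentage points lower from compound 2 to compound 3 (within the scatter), concerns the ester oxygen and is within the scatter.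

Compound 4 `NC(=O)C[C@H](NC(=O)CN(c1nc(Cl)nc2[nH]cnc12)C1CC1)C(=O)O` is not yet measured in this assay. It differs from compound 2 by carbamoyl in place of carbamoylmethyl on a saturated chain carbon, two bonds along the chain from an amide-type nitrogen and a carbonyl carbon. Within the data shown here, no measured step touches this chain; the step from compound 2 to compound 3 sits at another place and was itself flat. Nothing in the series points to a step beyond the scatter, so compound 4 is expected to show a number 2.4 percentage points lower from compound 2 to compound 4 (within the scatter). The estimate for compound 4 is 36%, with a range from 22% to 50%.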

Compound 4, a percentage reported as activity, at one dose (the size of the read-out at that dose, not a potency): 43.1%
Estimate against measurement, compound 4: 7.1 percentage points below; the range from low to high includes it.
By their numbers in this assay, from the lowest: compounds 3, 1, 2 and 4 (each within the scatter of the next).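

In this assay, within the data shown here, the side chain itself is now varied for the first time: carbamoyl in place of carbamoylmethyl gives a number 4.7 percentage points higher from compound 2 to compound 4 (within the scatter). The read-out therefore does not separate the 2-carbamoylethyl chain of compound 2 from the carbamoylmethyl chain of compound 4, so this position accepts the change without a step beyond the scatter at the dose given. Nothing measured here bears on the reason for this result.

From the compounds shown here alone, whether a longer chain, or a carboxylic acid or an amine in place of the carbamoyl group, would stay as close to compound 2 remains open. Also open, going by these compounds, is whether the two chains would still read alike at other doses, since a read-out at one dose is no measure of potency.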